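The source may hold more compounds than are shown below. What is called first, only, known or untested is meant among the compounds shown, and "the series" means these compounds.

Compound 1 `CC(=O)Nc1cccc(S(=O)(=O)Oc2ccccc2C(C)C)c1` and compound 2 `CCCCCC(=O)Nc1cccc(S(=O)(=O)Oc2ccccc2C(C)C)c1` share one core and differ only in the chain attached to the carbonyl carbon of the amide. In a functional assay on MCF7 cells (Homo sapiens) for antiproliferative activity, read by sulforhodamine B assay, with a stated time of 48 h (a higher number here means a weaker inhibitor, a lower number a stronger inhibitor), compound 1 gives 21000 nM, and in this assay compound 2 gives 12000 nM. The step between them, a 1.8-fold lower number from compound 1 to compound 2 (0.24 log units; within the scatter), is too small to count as a real change. Among the compounds with values here, compound 2 therefore stands at the lowest of the two numbers seen so far, with compound 1 as its only neighbour, and the two cannot be told apart on these numbers.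

Compound 3 `CC(C)c1ccccc1OS(=O)(=O)c1cccc(NC(=O)C(C)(C)C)c1` has not yet been measured. It differs from compound 2 in one place: tert-butyl in place of pentyl on a carbonyl carbon. Within the data shown here, the only measured step that bears on this change is the exchange of hydrogen for butyl at the same part of the molecule, a 1.8-fold lower number from compound 1 to compound 2 (0.24 log units; within the scatter), which stayed within the scatter. Since lengthening the chain did little, reshaping it into a branched group is expected to do little as well, and the expected step is a 1.3-fold higher number from compound 2 to compound 3 (0.10 log units; within the scatter). For compound 3 the estimate in this assay is 15000 nM, with a likely range from 6000 nM to 40000 nM.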

Compound 3, half-maximal inhibitory concentration: 14000 nM
The estimate for compound 3 lay 1.1-fold (0.03 log units) above the measured number; measured number inside the range.
By their numbers in this assay, from the lowest: compounds 2, 3 and 1 (each within the scatter of the next).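

In this assay, the shape of the carbon group on the carbonyl carbon makes no readable difference so far: exchanging the unbranched pentyl for the branched tert-butyl gives a 1.2-fold higher number from compound 2 to compound 3 (0.07 log units; within the scatter). The same group set against the methyl of compound 1 gives a 1.5-fold lower number from compound 1 to compound 3 (0.18 log units; within the scatter), so methyl, pentyl and tert-butyl at this place all lie within the scatter of one another, and the three compounds cannot be ranked. No measurement available here accounts for this flat result.

Going by these compounds, all three groups at this place are built from carbon and hydrogen alone, so it remains open whether a group of another kind, such as an amine, a carboxylic acid or a phenyl ring on the same carbonyl carbon, would move the number beyond the scatter. On these data alone, it also remains open whether this insensitivity holds for a much longer chain, or whether it would persist if the rest of the shared core were altered.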